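Swapping 4-fluorophenyl for pyridin-2-yl: a clearance estimate

A few compounds are considered here, and "the series" means these few. Any claim that something is new, unique, unknown or untested is made for them only; others in the source may bear on it.

Measured in an ADME assay (liver) for metabolic stability, with Liver microsome (Rattus norvegicus) as the target, using microsomes; on this read-out lower numbers stand for slow clearance and higher numbers for fast clearance:
compound 1 `Fc1ccccc1CNc1nnc(-c2c[nH]c3ncccc23)o1` gives 46 mL.min-1.g-1
compound 2 `Fc1ccc(CNc2nnc(-c3c[nH]c4ncccc34)o2)cc1` gives 58 mL.min-1.g-1

These two values lie within the scatter of each other, so compound 2 stands level with compound 1. The change to compound 3 `c1ccc(CNc2nnc(-c3c[nH]c4ncccc34)o2)nc1` puts pyridin-2-yl in place of 4-fluorophenyl on a saturated chain carbon bound to a nitrogen on an aromatic ring, counted in full as pyridin-2-yl in place of 4-fluorophenyl on a saturated chain carbon bound to a nitrogen on an aromatic ring. For the measured compounds named here, the only measured step at this place is a 1.3-fold higher number from compound 1 to compound 2 (0.10 log units; within the scatter) and it only exchanged one fluorophenyl for another, so no measured step shows what replacing the ring does. With so little guidance, only a small lean to a lower number is expected in this assay, estimated as a 1.5-fold lower number from compound 2 to compound 3 (0.18 log units; within the scatter) and possibly no more than scatter. Compound 3 is estimated at 38 mL.min-1.g-1 with an expected range from 15 mL.min-1.g-1 to 80 mL.min-1.g-1.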

Compound 3, intrinsic clearance in microsomes: 14 mL.min-1.g-1
Beside the measured number, compound 3's estimate is 2.7-fold (0.43 log units) above it; measured number below the stated range.
By their numbers in this assay, from the lowest: compound 3; then compounds 1 and 2 (each within the scatter of the next).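

In this assay, the two fluorophenyl compounds gave no sign that this place matters, but exchanging the ring does: pyridin-2-yl in place of 4-fluorophenyl gives a 4.1-fold lower number from compound 2 to compound 3 (0.62 log units; beyond the scatter), and in place of 2-fluorophenyl it gives a 3.3-fold lower number from compound 1 to compound 3 (0.52 log units; beyond the scatter). Both steps point to slower clearance, whichever fluorophenyl ring is replaced.

From the compounds shown here alone, whether a pyridin-3-yl ring, a simple phenyl ring or an amine on the chain would go the same way remains open. No measurement shown here accounts for the lower numbers with pyridin-2-yl.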